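Cyano on the benzamide of compound 3: expected potency

This account rests on a few compounds, and the source may have more. Where it says the series, first, only, none or still open, it means among the compounds named here.

Measured compounds:
- compound 1 `COc1ccc(OCC(=O)Nc2cccc(NC(=O)c3ccc(N(C)C)cc3)c2)cc1OC`; in an assay on isolated protein for inhibition of Rho-associated protein kinase 1 (Homo sapiens), read by scintillation counting, radiometric assay and 33P incorporation, with a stated time of 40 min, in the presence of a further agent that is not named here (on this read-out lower numbers stand for stronger inhibition and higher numbers for weaker inhibition), compound 1 gives > 10000 nM, which is a limit of the assay and not a number.
- compound 2 `CN(C)c1ccc(C(=O)Nc2cccc(NC(=O)COc3ccc4c(c3)OCCC4=O)c2)cc1`; compound 2 gives 144 nM.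
- compound 3 `O=C(COc1ccc2c(=O)ccoc2c1)Nc1cccc(NC(=O)c2ccccc2)c1`; compound 3 gives 120 nM.

Compound 3 carries the lowest of the two numbers shown, but its gap to compound 2 lies within the scatter, so the two cannot be ordered. Compound 1 sits at the limit (the limit of > 10000 nM in this assay, at which 1 of the 3 values shown sits).

Compound 4 `N#Cc1ccc(C(=O)Nc2cccc(NC(=O)COc3ccc4c(=O)ccoc4c3)c2)cc1` differs from compound 3 in one place: cyano in place of hydrogen on an aromatic carbon, in words cyano in place of hydrogen on an aromatic carbon.

For the measured compounds named here, the only measured step, an at least 69-fold lower number from compound 1 to compound 2 (1.84 log units; beyond the scatter), changes the aryloxy part and not the benzamide, so it does not bear directly on this change. Compound 2 and compound 3 differ in two places, among them the substituent on the benzamide ring, and their values lie within the scatter of each other. Going by the values given here, no measured step varies only the benzamide substituent. The expectation is therefore a step of no size beyond the scatter, a 1.3-fold higher number from compound 3 to compound 4 (0.10 log units; within the scatter).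

Compound 4 is estimated at 150 nM, with a range from 50 nM to 450 nM.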

Compound 4, half-maximal inhibitory concentration: 123 nM
Compound 4: the middle estimate sits 1.2-fold (0.09 log units) above what was measured, within the range that was stated.
By their numbers in this assay, from the lowest: compounds 3, 4 and 2 (each within the scatter of the next). At a limit, above all of these: compound 1.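

Cyano in place of hydrogen on the benzamide ring, para to a large group, is the only step shown that varies this ring alone, and in this assay it gives a 1.0-fold higher number from compound 3 to compound 4 (0.01 log units; within the scatter). The earlier compounds shown here could not show this, since compound 2 and compound 3 differ in two places. Going from benzamido to ((4-cyanophenyl)carbonyl)amino adds two heavy atoms and a hydrogen-bond acceptor at this place without a difference that can be read, so this position accepts the cyano group in this series. The data at hand offer no measurement that explains this result.

A single substituent does not define what this position tolerates: a carboxylic acid, a primary amine or a longer alkyl chain at the same place could still give a number beyond the scatter of compound 3. Going by these compounds, it also remains open whether the cyano group behaves in the same way with the aryloxy part of compound 2, which differs from compound 4 in more than one place.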